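A few compounds are considered here, and "the series" means these few. Any claim that something is new, unique, unknown or untested is made for them only; others in the source may bear on it.

Compound 1, `CS(=O)(=O)c1ccc(-c2cnc3[nH]cc(-c4nnc(-c5ccccc5)o4)c(=O)c3c2)cc1`: 8.58%
Compound 2, `CS(=O)(=O)c1ccc(-c2cnc3[nH]cc(-c4nnc(-c5ccc(Cl)cc5)o4)c(=O)c3c2)cc1`: 1.07%
Compound 3, `N#Cc1ccc(-c2cnc3[nH]cc(-c4nnc(-c5ccc(Cl)cc5)o4)c(=O)c3c2)cc1`: 4.8%

In a functional assay on HeLa cells (Homo sapiens) for inhibition, read by MTT assay, with a stated time of 24 h, tested at 5 uM (on this read-out higher numbers stand for more inhibition of growth at the one concentration tested and lower numbers for less inhibition of growth), compound 3 gives 4.8%. Compound 1 gives 8.58% and compound 2 gives 1.07%, so all three numbers lie close together and none of them can be told apart from another. The two measured steps confirm this: a number 7.5 percentage points lower from compound 1 to compound 2 (within the scatter), and a number 3.7 percentage points higher from compound 2 to compound 3 (within the scatter).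

Compound 4, `O=c1c(-c2nnc(-c3ccc(Cl)cc3)o2)c[nH]c2ncc(-c3ccccc3)cc12`, differs from compound 3 by hydrogen in place of cyano on an aromatic carbon. Among the measured compounds shown here, the only measured step that touches this same position is the one from compound 2 to compound 3, where cyano replaced methylsulfonyl, and that step stayed within the scatter. For the measured compounds named here, no measured step removes the group at this position altogether, so the expectation rests on that single comparison and on the narrow spread of all three numbers. The step is therefore expected to be a number 0.2 percentage points higher from compound 3 to compound 4 (within the scatter), with no change beyond the scatter. For compound 4 the estimate in this assay is 5%, within a range from -6% to 16%.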

Compound 4, percent growth inhibition at one concentration: 3.55%
Estimate against measurement, compound 4: 1.5 percentage points above; low and high end bracket the measured number.
By their numbers in this assay, from the lowest: compounds 2, 4, 3 and 1 (each within the scatter of the next).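

In this assay, going from 4-cyanophenyl to phenyl gives a number 1.3 percentage points lower from compound 3 to compound 4 (within the scatter) and putting hydrogen in place of methylsulfonyl on the same carbon gives a number 2.5 percentage points higher from compound 2 to compound 4 (within the scatter) with the rest of the molecule unchanged. Among the compounds shown here, the earlier compounds compared only two groups at this place, and now a ring carrying no group there cannot be told apart from either of them, so methylsulfonyl, cyano and hydrogen read alike at the one concentration tested. No measurement at hand offers an explanation for this.

From the compounds shown here alone, whether an amine or a carboxylic acid on this carbon would give a number beyond the scatter stays open. Also open, going by these compounds, is whether these compounds would separate at a concentration other than the one tested.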